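A few compounds are considered here, and "the series" means these few. Any claim that something is new, unique, unknown or untested is made for them only; others in the source may bear on it.

Measured so far:
compound 1, `COc1ccc2c(-c3cc(C(F)(F)F)c(C#N)c(-c4cn(S(=O)(=O)c5ccc(C)cc5)c5cc(OC)ccc45)n3)cn(S(=O)(=O)c3ccc(C)cc3)c2c1`: 9.1%
compound 2, `Cc1ccc(S(=O)(=O)n2cc(-c3cc(C(F)(F)F)ccn3)c3ccccc32)cc1`: 10.5%

In a functional assay on P388 cells (Mus musculus) for inhibition, tested at 1 uM (a higher number here means a stronger effect of the compound at the concentration tested, a lower number a weaker effect), compound 2 gives 10.5%, the higher of the two numbers recorded. Compound 1 gives 9.1% in this assay; the gap to compound 2 lies within the scatter, so the two readings cannot be told apart and neither compound can be called the stronger one. Both readings sit at the low end of the scale.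

Compound 3, `Cc1ccc(S(=O)(=O)n2cc(-c3cc(C(F)(F)F)ccn3)c3cc(Br)ccc32)cc1`, has not been measured. It differs from compound 2 in one place: bromo in place of hydrogen on an aromatic carbon.

Among the compounds with values here, no step between measured compounds is available, so nothing measured shows what this change does in this assay. Within the data shown here, the only anchor is the reading of compound 2 itself, and the step in this assay is expected to be small, of no set direction, and not beyond the scatter, which the estimate renders as a number 1.5 percentage points higher from compound 2 to compound 3 (within the scatter). On that basis compound 3 is estimated at 12% in this assay, with a range from 2% to 26% to be checked once the measurement is in hand.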

Compound 3, a percentage reported as inhibition, at one concentration (the size of the read-out at that concentration, not a potency): 17.8%
For compound 3 the middle estimate is 5.8 percentage points below the measured one; measured number inside the range.
By their numbers in this assay, from the lowest: compounds 1, 2 and 3 (each within the scatter of the next).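

In this assay, bromo in place of hydrogen on an aromatic carbon, in the six-membered aromatic ring of carbon only that is part of a fused or bridged system of two rings, gives a number 7.3 percentage points higher from compound 2 to compound 3 (within the scatter). Within the data shown here, this is the first one-place step available, and it shows that a bromo at this position leaves compound 3 indistinguishable from compound 2 in this read-out, so the exchange gives no detectable gain or loss of effect at the concentration tested. Nothing at hand bears on the reason for this reading, and the size of the step therefore carries no explanation.

Still open, on these data alone, is whether the insensitivity belongs to this position or only to this exchange: a fluoro, a methoxy group, an amine or a carboxylic acid on the same aromatic carbon could separate from compound 2 by more than the scatter. As far as these compounds go, it is equally open whether bromo on another carbon of that ring, or on the ring bearing the trifluoromethyl group, would give a step that can be told from the scatter.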